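The source may report more compounds than this note shows. Statements on the series, on what has been measured and on what is new or still open speak of the compounds shown alone.

In a functional assay on A549 cells (Homo sapiens) for antiproliferative activity, read by sulforhodamine B assay, with a stated time of 48 h (on this read-out lower numbers stand for stronger inhibition of growth and higher numbers for weaker inhibition of growth), compound 1 `COc1ccc(Nc2nc(NCCCO)c3ccccc3n2)cc1` gives 15200 nM. Compound 2 `N#Cc1ccc(Nc2nc(NC3CCCC3)c3ccccc3n2)cc1` is recorded at > 31300 nM, and this is a limit of the assay rather than a measured number. Among the compounds with values here, its true position is therefore unknown, and no exact step can be counted from it. Compound 3 `N#Cc1ccc(Nc2nc(NCCCO)c3ccccc3n2)cc1` differs from compound 2 in one place: 3-hydroxypropyl in place of cyclopentyl on a nitrogen on an aromatic ring. In words, 3-hydroxypropyl stands in place of cyclopentyl on a nitrogen on an aromatic ring. Compound 1 also carries a 3-hydroxypropyl group, and the expectation of a modest gain in growth inhibition rests on compound 1 giving a real number, 15200 nM. The expected change is an estimated at least 1.5-fold lower number from compound 2 to compound 3 (0.19 log units; that floor lies within the scatter), and the result could still turn out to be a limit. For compound 3 the expected value is 20000 nM, with an estimated range of 9000 nM to 40000 nM.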

Compound 3, concentration for 50% growth inhibition: 3000 nM
Estimate against measurement, compound 3: 6.7-fold (0.82 log units) above; the whole stated range lies above it.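

In this assay, the nitrogen carrying the side chain proves to be a place where a single change can matter: with cyano held fixed, 3-hydroxypropyl in place of cyclopentyl gives an at least 10-fold lower number from compound 2 to compound 3 (1.01 log units; beyond the scatter). Compound 2 stands only at a limit of the assay, and this step is therefore a floor and not an exact size: the limit of > 31300 nM in this assay, at which 1 of the 3 values shown sits. With 3-hydroxypropyl held fixed, the aromatic carbon is a second place that counts, as cyano in place of methoxy gives a 5.1-fold lower number from compound 1 to compound 3 (0.70 log units; beyond the scatter).

The compounds shown leave open whether the hydroxyl group or the loss of the cyclopentyl ring matters more, a question that a plain propyl chain on the same nitrogen would help separate. A longer chain ending in hydroxyl, or a chain ending in an amine, could show how far this side chain can be varied.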